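The compounds below may be only part of what the source reports. "The series", "measured", "known", "first", "only" and "open" are said of these compounds alone.

Measured so far in an assay on CHO-K1 cells for displacement of a labelled ligand from prostaglandin E2 receptor EP1 subtype (Homo sapiens), read by scintillation counting, with a stated time of 45 min; on this read-out lower numbers stand for stronger inhibition and higher numbers for weaker inhibition:
Compound 1 `Cc1cc(C(=O)O)nn1Cc1cc(Cl)cc2cc(C3CCCCC3)oc12` — 3.98 nM
Compound 2 `Cc1cc(C(=O)NC2CC2)nn1Cc1cc(Cl)cc2cc(-c3ccccc3)oc12` — 5.01 nM
Compound 3 `Cc1cc(C(=O)NCC2CCNCC2)nn1Cc1cc(Cl)cc2cc(-c3ccccc3)oc12` — 20 nM

Compound 3 gives the highest number of the three; compound 2 lies nearest to it, and compound 1 lies furthest from it. Compound 4 `Cc1cc(C(=O)NCC(O)C(F)(F)F)nn1Cc1cc(Cl)cc2cc(-c3ccccc3)oc12` has not yet been measured in this assay. It differs from compound 3 in one place: 2,2,2-trifluoro-1-hydroxyethyl in place of piperidin-4-yl on a saturated chain carbon bound to an amide-type nitrogen.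

Among the measured compounds shown here, only one measured step bears on this change, and it touches the same amide-type nitrogen: a 4.0-fold higher number from compound 2 to compound 3 (0.60 log units; beyond the scatter). That step showed that the small cyclopropyl group on the amide is tolerated better than the larger (piperidin-4-yl)methyl group. Since the change to compound 4 removes the piperidin-4-yl ring and puts a short, ring-free chain in its place, a step back toward the number of compound 2 is expected, that is, a modest lowering, though the new group is not the same as cyclopropyl and the comparison is loose.

Compound 4 is therefore estimated to give 8 nM in this assay, with a range from 3 nM to 25 nM; this corresponds to an expected step of a 2.5-fold lower number from compound 3 to compound 4 (0.40 log units; beyond the scatter).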

Compound 4, half-maximal inhibitory concentration: 25.1 nM
For compound 4 the middle estimate is 3.1-fold (0.50 log units) below the measured one, and the stated range ends below it.
By their numbers in this assay, from the lowest: compounds 1 and 2 (each within the scatter of the next); then compounds 3 and 4 (each within the scatter of the next).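

In this assay, the step of a 1.3-fold higher number from compound 3 to compound 4 (0.10 log units; within the scatter) shows that the ring-free 2,2,2-trifluoro-1-hydroxyethyl group and piperidin-4-yl cannot be told apart at this position on a saturated chain carbon bound to an amide-type nitrogen, so the six-membered ring and its nitrogen are not required for the number seen with compound 3. The step from the cyclopropyl amide, a 5.0-fold higher number from compound 2 to compound 4 (0.70 log units; beyond the scatter), runs in the same direction and also lies beyond the scatter, as does a 4.0-fold higher number from compound 2 to compound 3 (0.60 log units; beyond the scatter), so two chains of quite different make-up both stand apart from cyclopropyl. Nothing available explains this result.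

Going by these compounds, it remains open whether a plain propyl chain on the amide nitrogen would group with compound 2 or with compounds 3 and 4. On these data alone, it is also open whether the hydroxyl or the trifluoromethyl part of the new group matters, taken alone.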